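Swapping the Outer Ring of Compound 3

The source may hold more compounds than are shown below. What is called first, only, known or untested is meant among the compounds shown, and "the series" means these compounds.

In a functional assay on the whole organism (liver, strain NMRI) for inhibition, with Mus musculus as the target, with a stated time of 3 h, at a dose of 3 mg/kg by the oral route (on this read-out higher numbers stand for more inhibition at the one dose given (going by the name of the read-out) and lower numbers for less inhibition), compound 3 `Cc1cc(-c2cc(-c3cc(O)c(O)c([N+](=O)[O-])c3)on2)on1` gives 32.4%. Compound 2 `O=[N+]([O-])c1cc(-c2nc(-c3cccs3)no2)cc(O)c1O` gives 29.6%, which lies within the scatter of that number, while compound 1 `O=[N+]([O-])c1cc(-c2nc(-c3ccc(F)cc3)no2)cc(O)c1O` gives 12.7%, which lies beyond it. Among the measured compounds shown here, the only step measured so far is a number 16.9 percentage points higher from compound 1 to compound 2 (beyond the scatter), where one outer ring replaced another on an aromatic carbon. Compound 4 `O=[N+]([O-])c1cc(-c2cc(-c3cnccn3)no2)cc(O)c1O` makes a similar kind of exchange: pyrazin-2-yl in place of 3-methyl-1,2-oxazol-5-yl on an aromatic carbon. For the measured compounds named here, since the one measured exchange of an outer ring was modest, and no measured step replaces 3-methyl-1,2-oxazol-5-yl with pyrazin-2-yl, the expectation is a step of a number 2.4 percentage points lower from compound 3 to compound 4 (within the scatter), not clearly beyond the scatter. Compound 4 is therefore estimated at 30%, between 10% and 50%.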

Compound 4, a percentage reported as inhibition, in the whole organism at one dose (the size of the read-out at that dose, not a potency): 44.7%
For compound 4 the middle estimate is 14.7 percentage points below the measured one, and the stated range covers the measured number.
By their numbers in this assay, from the lowest: compound 1; then compounds 2 and 3 (each within the scatter of the next); then compound 4.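

In this assay the exchange of 3-methyl-1,2-oxazol-5-yl for pyrazin-2-yl gives a step beyond the scatter (a number 12.3 percentage points higher from compound 3 to compound 4 (beyond the scatter)), so the outer ring at this position also matters in a compound with a different core from compound 1 and compound 2. The two groups have the same counts of heavy atoms, hydrogen-bond donors and hydrogen-bond acceptors, so those counts alone do not set the number here. Nothing at hand explains the step. From the compounds shown here alone, whether pyrazin-2-yl would give a similar step on the core of compound 1 stays open. So does the effect of a non-aromatic group here, such as an amine or a carboxylic acid.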